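A few compounds are considered here, and "the series" means these few. Any claim that something is new, unique, unknown or untested is made for them only; others in the source may bear on it.

Working notes on the series. Compound 3, `N#CC1=C(N)Oc2c(N)cc3nc4ccccc4nc3c2C12C(=O)N(Cc1cnnn1-c1c(F)cccc1F)c1ccccc12`, is so far known only by a limit of this assay: in a functional assay on A549 cells (Homo sapiens) for antiproliferative activity, read by MTT assay, with a stated time of 48 h (on this read-out lower numbers stand for stronger inhibition and higher numbers for weaker inhibition), compound 3 gives > 50000 nM, which is a limit and not a number. The two other members stand the same way. Compound 1, `N#CC1=C(N)Oc2c(N)cc3nc4ccccc4nc3c2C12C(=O)N(Cc1cnnn1-c1ccc(Cl)cc1)c1ccccc12`, gives in this assay > 50000 nM, a limit. Compound 2, `CCc1cccc(C)c1-n1nncc1CN1C(=O)C2(C(C#N)=C(N)Oc3c(N)cc4nc5ccccc5nc4c32)c2ccccc21`, gives in this assay > 50000 nM, again a limit. Taken together, (the limit of > 50000 nM in this assay, at which 3 of the 3 values shown sit). The three steps among them are therefore not readable in size: a step that the two limits leave unreadable from compound 1 to compound 2, a step that the two limits leave unreadable from compound 1 to compound 3 and a step that the two limits leave unreadable from compound 2 to compound 3 all run between two limits, and none of them can be read as a change in either direction.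

The next member, compound 4, `N#CC1=C(N)Oc2c(N)cc3nc4ccccc4nc3c2C12C(=O)N(Cc1cnnn1-c1ccc(Cl)cc1Cl)c1ccccc12`, differs from compound 3 in a single place: 2,4-dichlorophenyl in place of 2,6-difluorophenyl on an aromatic nitrogen. All three measured steps bear on it, since each swaps one aryl group on the same aromatic nitrogen, and each was left unreadable by the limit. Nothing in the measured set points to a readable gain or loss for this swap, so the expectation for compound 4 in this assay is a step that the limit leaves unreadable from compound 3 to compound 4 that stays hidden behind the limit. Compound 4 is estimated at 60000 nM, with a range from 20000 nM to 200000 nM.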

Compound 4, half-maximal inhibitory concentration: > 50000 nM
Compound 4 ended at the assay's limit (the forecaster's own chance of this, stated with the estimate: 85%); the middle value is on the limit's open side.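

Compound 4 adds no readable step: its links to compound 1, compound 2 and compound 3 all run between two limits and cannot be read in size. The compounds shown leave open whether any aryl group on this aromatic nitrogen gives a measurable value in this assay, and how such groups would rank there.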